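The source may hold more compounds than are shown below. What is called first, only, known or untested is meant among the compounds shown, and "the series" means these compounds.

Measured so far in a functional assay on the whole organism with Rattus norvegicus as the target; on this read-out lower numbers stand for an effect already at smaller amounts and higher numbers for an effect only at larger amounts of compound:
compound 1 `CCc1nnc(-c2cn3c(C)c(CC)c(OC)nc3n2)o1` gives 50 mg/kg
compound 2 `CCCc1nnc(-c2cn3c(C)c(CC)c(OC)nc3n2)o1` gives 50 mg/kg
compound 3 `CCc1c(OC)nc2nc(-c3nnc(-c4ccccc4)o3)cn2c1C` gives only a limit of the assay, > 50 mg/kg

Compound 1 stands level with compound 2 within the scatter, the methyl added on the chain giving no change at the digits printed from compound 1 to compound 2 (within the scatter). Putting phenyl in place of ethyl gave a number no lower from compound 1 to compound 3 (the limit leaves the size open), the size not readable because compound 3 sits at the limit (the limit of > 50 mg/kg in this assay, at which 1 of the 3 values shown sits).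

Compound 4 `CCc1c(OC)nc2nc(-c3nc(C)no3)cn2c1C` carries 3-methyl-1,2,4-oxadiazol-5-yl in place of 5-ethyl-1,3,4-oxadiazol-2-yl on an aromatic carbon. Neither measured step touches the ring itself; both only vary the substituent on it, and neither shows a drop. A step beyond the scatter is therefore not expected. The expected step is no change at the digits printed from compound 1 to compound 4 (within the scatter). Compound 4 is estimated at 50 mg/kg, between 25 mg/kg and 100 mg/kg.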

Compound 4, minimum effective dose: 5 mg/kg
The estimate for compound 4 lay 10-fold (1.00 log units) above the measured number; the measured number lies below the stated range.
By their numbers in this assay, from the lowest: compound 4; then compounds 1 and 2 (each within the scatter of the next).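

In this assay, for the compounds shown here, the exchange of 5-ethyl-1,3,4-oxadiazol-2-yl for 3-methyl-1,2,4-oxadiazol-5-yl gives a 10-fold lower number from compound 1 to compound 4 (1.00 log units; beyond the scatter) and is the only readable step beyond the scatter. This position on the shared core therefore does respond, though only to a change of ring arrangement and substituent taken together, while the added chain methyl alone left compound 1 and compound 2 level.

From the compounds shown here alone, whether the step belongs to the ring arrangement or to methyl in place of ethyl stays open; 3-ethyl-1,2,4-oxadiazol-5-yl or 5-methyl-1,3,4-oxadiazol-2-yl would separate the two. Nothing shown gives a cause for this step.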